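The compounds below may be only part of what the source reports. "The series", "measured", "known", "first", "only" and "open" are said of these compounds alone.

In a toxicity assay on MT2 cells (Homo sapiens) for cytotoxicity, read by XTT assay, with a stated time of 4 days (on this read-out higher numbers stand for lower toxicity in this test and lower numbers for higher toxicity in this test), compound 2 `Cc1nc(C)c([C@H](OC(C)(C)C)C(=O)O)c(N2CCC(C)(C)CC2)c1-c1ccc(OCCc2ccc(Cl)cc2)cc1` stands only at a limit: compound 2 gives >= 33500 nM, which is a limit of the assay and not a measured number. Compound 1 `COc1ccc(CCOc2ccc(-c3c(C)nc(C)c([C@H](OC(C)(C)C)C(=O)O)c3N3CCC(C)(C)CC3)cc2)cc1` stands at the same kind of limit; in this assay compound 1 gives >= 33500 nM. Within the data shown here, the one measured step, a step that the two limits leave unreadable from compound 1 to compound 2, therefore cannot be read in size or direction, and the whole picture rests on (the limit of >= 33500 nM in this assay, at which 2 of the 2 values shown sit).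

Compound 3 `Cc1nc(C)c([C@H](OC(C)(C)C)C(=O)O)c(N2CCC(C)(C)CC2)c1-c1ccc(SCCc2ccc(F)cc2)cc1` is not yet measured and differs from compound 2 by (2-(4-fluorophenyl)ethyl)sulfanyl in place of 2-(4-chlorophenyl)ethoxy on an aromatic carbon. Among the measured compounds shown here, no measured step bears on this change with a readable size, so no step beyond the scatter is expected in this assay in either direction. Compound 3 is expected to give about 33500 nM, within a range from 15000 nM to 60000 nM. That estimate corresponds to an expected step of a number no higher from compound 2 to compound 3 (the limit leaves the size open).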

Compound 3, half-maximal cytotoxic concentration: >= 32000 nM
Compound 3: a limit, no number; the forecaster's own chance of this, stated with the estimate: 75%; the middle value does not contradict the limit.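

In this assay compound 3 gives >= 32000 nM, which is a limit and not a number. Among these compounds, with compound 1, compound 2 and compound 3 all at limits, no step among them can be read. The compounds shown leave open whether either change shifts the half-maximal cytotoxic concentration at all.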